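The source may report more compounds than this note shows. Statements on the series, on what has been measured and on what is new or still open speak of the compounds shown alone.

Measured in a functional assay on MDA-MB-231 cells (Homo sapiens) for antiproliferative activity, with a stated time of 4 days; on this read-out lower numbers stand for stronger inhibition and higher numbers for weaker inhibition:
- compound 1 `CCCCc1ccc2[nH]c(-c3ccc(OC)cc3)c(C=O)c2c1`: 6.7 nM
- compound 2 `CCCCc1ccc2[nH]c(-c3ccc(C(F)(F)F)cc3)c(C=O)c2c1`: 33 nM
- compound 3 `CCCCc1ccc2[nH]c(-c3ccc(CC)cc3)c(C=O)c2c1`: 27 nM

Compound 1 holds the lowest number of the three, and both steps away from it lie beyond the scatter: a 4.9-fold higher number from compound 1 to compound 2 (0.69 log units; beyond the scatter) and a 4.0-fold higher number from compound 1 to compound 3 (0.61 log units; beyond the scatter). The other two values do not separate: a 1.2-fold lower number from compound 2 to compound 3 (0.09 log units; within the scatter).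

Next in this assay is compound 4 `COc1ccc(-c2[nH]c3ccc(C)cc3c2C=O)cc1`. The change from compound 1 is hydrogen in place of propyl on a saturated chain carbon bound to an aromatic carbon, or butyl to methyl when cut one bond further out.

For the measured compounds named here, no measured step touches this chain, since all three changes sit on the other side of the molecule, at the group that carries methoxy in compound 1. They therefore bear on the question only indirectly. Each departure from compound 1 so far gave a modest rise, as in a 4.0-fold higher number from compound 1 to compound 3 (0.61 log units; beyond the scatter), and this is a weak precedent from three compounds. A step of similar or somewhat larger size towards a higher number is expected, with wide uncertainty. The expected change is a 4.5-fold higher number from compound 1 to compound 4 (0.65 log units; beyond the scatter). Compound 4 is estimated at 30 nM, with an expected range of 9 nM to 110 nM.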

Compound 4, half-maximal inhibitory concentration: 86 nM
Beside the measured number, compound 4's estimate is 2.9-fold (0.46 log units) below it; the measured number falls inside the stated range.
By their numbers in this assay, from the lowest: compound 1; then compounds 3 and 2 (each within the scatter of the next); then compound 4.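

In this assay, for the compounds shown here, the chain is the first site to give a large step: cutting butyl back to methyl, with methoxy kept in place, produces a 13-fold higher number from compound 1 to compound 4 (1.11 log units; beyond the scatter) and so shows that this position has a strong bearing on the read-out. The earlier compounds shown here varied only the group that carries methoxy in compound 1, and their steps, such as a 4.9-fold higher number from compound 1 to compound 2 (0.69 log units; beyond the scatter) and a 4.0-fold higher number from compound 1 to compound 3 (0.61 log units; beyond the scatter), were modest, so they gave no measure of how much the butyl chain contributes. Nothing available explains why removing propyl at this saturated chain carbon costs so much.

From the compounds shown here alone, with only butyl and methyl on record, the shape of the chain-length trend remains open: an ethyl, propyl or hexyl chain, or a butyl chain ending in an amine or a carboxylic acid, could show whether the number keeps falling with length, levels off or turns upward. It is also open whether shortening the chain would give a step of similar size with trifluoromethyl or ethyl in place of methoxy, since the only chain step shown carries methoxy.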